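Trimming the sulfonamide chain of compound 1 to methyl

The source may report more compounds than this note shows. Statements on the series, on what has been measured and on what is new or still open speak of the compounds shown alone.

Compound 1 `CCCNS(=O)(=O)c1ccc(Nc2ncc3c(n2)N(C2CCCC2)[C@H](CC)C(=O)N3C)cc1` carries a propylsulfamoyl group on the aniline that links into the shared core. In a functional assay on MCF7 cells (Homo sapiens) for antiproliferative activity, read by CCK-8 assay, with a stated time of 72 h (on this read-out higher numbers stand for weaker inhibition of growth and lower numbers for stronger inhibition of growth), compound 1 gives 344 nM. Compound 3 `CCCNC(=O)c1ccc2c(ccn2-c2ncc3c(n2)N(C2CCCC2)[C@H](CC)C(=O)N3C)c1` replaces that aniline with an indole bearing a propylcarbamoyl group and, in this assay, compound 3 gives 592 nM; the two values sit within the scatter of each other, so no order between compound 1 and compound 3 can be read from them. Compound 2 `CCC1C(=O)N(C)c2cnc(-n3ccc4cc(C(N)=O)ccc43)nc2N1c1ccn(C)n1` carries a different carboxamide indole and a different group on the core, and in this assay compound 2 gives "not active" (no number reported), without a number. Among the two numbers shown, compound 1 has the lowest.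

Compound 4 `CC[C@@H]1C(=O)N(C)c2cnc(Nc3ccc(S(=O)(=O)NC)cc3)nc2N1C1CCCC1` has not yet been measured. It differs from compound 1 in one place: hydrogen in place of ethyl on a saturated chain carbon bound to a sulfonamide nitrogen. In other words, propylsulfamoyl becomes methylsulfamoyl. Within the data shown here, no measured pair in this set shows what shortening such a chain does here, so the direction of the step is uncertain. The expectation is that the step of a 1.3-fold higher number from compound 1 to compound 4 (0.12 log units; within the scatter) stays within the scatter or drifts slightly toward weaker inhibition. Compound 4 is therefore estimated at 450 nM, within a range from 180 nM to 1200 nM.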

Compound 4, concentration for 50% growth inhibition: 151 nM
The estimate for compound 4 lay 3.0-fold (0.47 log units) above the measured number, outside the stated range (below it).
By their numbers in this assay, from the lowest: compound 4; then compounds 1 and 3 (each within the scatter of the next).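

In this assay, among these compounds, the change from propylsulfamoyl to methylsulfamoyl gives a 2.3-fold lower number from compound 1 to compound 4 (0.36 log units; beyond the scatter), a modest step beyond the scatter, and this is the first pair in the set that differs in one place only. It shows that this position, on a saturated chain carbon bound to a sulfonamide nitrogen, responds to the change, and that the full propyl chain is not required for the inhibition of growth seen with compound 1, since removing the ethyl part goes with stronger inhibition. Nothing shown here explains the step, which therefore stands as an observation without a stated cause.

All of this rests on a single pair, so the compounds shown leave open whether the number would keep falling with plain hydrogen on the sulfonamide nitrogen, or how an ethyl group, a longer chain such as butyl, or a chain ending in an amine or a carboxylic acid would behave there. They also leave open whether the same trimming would carry over to the propylcarbamoyl group of compound 3.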